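Dropping one hydroxy on the hydrazone phenyl ring

The source may hold more compounds than are shown below. What is called first, only, known or untested is meant among the compounds shown, and "the series" means these compounds.

Compound 3 `COc1ccccc1-c1nnc(-c2ccc(C(=O)N/N=C/c3ccc(O)c(O)c3)cc2)o1` gives 100000 nM in an ADME assay on THP-1 cells (Homo sapiens) for cytotoxicity (on this read-out higher numbers stand for weaker inhibition and lower numbers for stronger inhibition), level with compound 1 `COc1ccccc1-c1nnc(-c2ccc(C(=O)N/N=C/c3cc(O)ccc3O)cc2)o1`, which gives 100000 nM, the two together at the low end of the three numbers. Compound 2 `COc1ccccc1-c1nnc(-c2ccc(C(=O)N/N=C/c3cccc(O)c3)cc2)o1` sits furthest away with 398000 nM. Compound 4 `COc1ccccc1-c1nnc(-c2ccc(C(=O)N/N=C/c3ccccc3O)cc2)o1` differs from compound 3 in one place: 2-hydroxyphenyl in place of 3,4-dihydroxyphenyl on a carbon with a double bond to nitrogen. Among the measured compounds shown here, two measured steps bear on this, both changing the count of hydroxy groups on that ring: a 4.0-fold higher number from compound 1 to compound 2 (0.60 log units; beyond the scatter) and a 4.0-fold lower number from compound 2 to compound 3 (0.60 log units; beyond the scatter). The exchange of one dihydroxy pattern for another, no change at the digits printed from compound 1 to compound 3 (within the scatter), moved nothing. Since compound 4 also carries a single hydroxy, a modest rise in this assay is expected, roughly a 3.0-fold higher number from compound 3 to compound 4 (0.48 log units; beyond the scatter). Compound 4 is therefore estimated at 300000 nM, within 100000 nM to 900000 nM.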

Compound 4, half-maximal inhibitory concentration: 207000 nM
Compound 4: the middle estimate sits 1.4-fold (0.16 log units) above what was measured; measured number inside the range.
By their numbers in this assay, from the lowest: compounds 1 and 3 (each within the scatter of the next); then compounds 4 and 2 (each within the scatter of the next).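

On the carbon with a double bond to nitrogen, 2-hydroxyphenyl sits with 3-hydroxyphenyl apart from the dihydroxy compounds in this assay, with a 2.1-fold higher number from compound 3 to compound 4 (0.32 log units; beyond the scatter) and a 2.1-fold higher number from compound 1 to compound 4 (0.32 log units; beyond the scatter). Where the single hydroxy stands on the ring does not register, with a 1.9-fold lower number from compound 2 to compound 4 (0.28 log units; within the scatter). A second hydroxy now lowers the number from both single-hydroxy compounds, and this holds across two pairs: the same change on two cores in this assay, a 4.0-fold lower number (0.60 log units; beyond the scatter) from compound 2 to compound 3 and a 2.1-fold lower number (0.32 log units; beyond the scatter) from compound 4 to compound 1, 1.9-fold (0.28 log units) apart, within the scatter of two such steps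

The compounds shown leave open how a plain phenyl ring, or an amine or a carboxylic acid in place of the hydroxy, would read in this assay.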